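This account rests on a few compounds, and the source may have more. Where it says the series, first, only, none or still open, it means among the compounds named here.

Measured in an ADME assay for permeability, using PAMPA, in phosphate buffer, with a stated time of 18 h, at pH 7.4; a higher number here means that the compound crosses the layer faster, a lower number that the compound crosses the layer more slowly:
- compound 1, `Cn1cc(-c2cc(-c3cc(Cl)cc(OCC4CC4)c3)c(=O)n(-c3cccnc3)c2)c(=O)[nH]c1=O`: 3.25 10^-6 cm/s
- compound 2, `Cn1cc(-c2cc(-c3cc(Cl)cc(OCc4ocnc4C(F)(F)F)c3)c(=O)n(-c3cccnc3)c2)c(=O)[nH]c1=O`: 1.03 10^-6 cm/s

Going by the values given here, compound 2 holds the lowest of the two numbers in this assay; the single step on record, a 3.2-fold lower number from compound 1 to compound 2 (0.50 log units; beyond the scatter), separates it from compound 1. Compound 3, `Cn1cc(-c2cc(-c3cc(Cl)cc(OCc4scnc4C(F)(F)F)c3)c(=O)n(-c3cccnc3)c2)c(=O)[nH]c1=O`, is not yet measured. It differs from compound 2 in one place: a group of 9 heavy atoms (4 carbon, 1 nitrogen, 3 fluorine, 1 sulfur; one five-membered aromatic ring with 2 hetero atoms) in place of a group of 9 heavy atoms (4 carbon, 1 nitrogen, 1 oxygen, 3 fluorine; one five-membered aromatic ring with 2 hetero atoms), on a saturated chain carbon bound to an oxygen on an aromatic ring. Among the compounds with values here, the recorded step exchanged the three-membered ring for the whole five-membered aromatic ring and therefore says little about swapping one ring hetero atom (oxygen) for another (sulfur) while the trifluoromethyl and the rest of the molecule stay fixed; no step of that kind exists. The expectation is a small move, at most a marginally higher number, a 1.4-fold higher number from compound 2 to compound 3 (0.13 log units; within the scatter), which may well stay inside the scatter. Compound 3 is thus estimated at 1.4 10^-6 cm/s, with a range of 0.7 10^-6 cm/s to 3 10^-6 cm/s.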

Compound 3, apparent permeability in the ADME assay: 1.16 10^-6 cm/s
Estimate against measurement, compound 3: 1.2-fold (0.08 log units) above, and the stated range covers the measured number.
By their numbers in the ADME assay, from the lowest: compounds 2 and 3 (each within the scatter of the next); then compound 1.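

In the ADME assay compound 2 gives 1.03 10^-6 cm/s and compound 3 gives 1.16 10^-6 cm/s; the exchange of ring oxygen for sulfur gives a 1.1-fold higher number from compound 2 to compound 3 (0.05 log units; within the scatter) on the saturated chain carbon bound to an oxygen on an aromatic ring, so the two trifluoromethyl-bearing rings cannot be told apart here. In the ADME assay the sulfur ring also shows a 2.8-fold lower number from compound 1 to compound 3 (0.45 log units; beyond the scatter) in place of the three-membered ring, so compound 2 and compound 3 both stand beyond the scatter from compound 1, on the lower side. In a physicochemical assay for solubility, using the shake flask method, with a stated time of 48 h, at pH 6.5 (on this read-out lower numbers stand for lower solubility and higher numbers for higher solubility), compound 2 gives 34.5 ug/mL and compound 3 gives 24.8 ug/mL; the same exchange gives a 1.4-fold lower number from compound 2 to compound 3 (0.14 log units; within the scatter) and again separates neither compound.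

No measured evidence bearing on the cause of these results is at hand. The compounds shown do not separate the effect of the five-membered aromatic ring from that of its trifluoromethyl, and a methyl group in place of the trifluoromethyl would speak to that question.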